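Chlorine on the Quinoline Ring: From Compound 2 to Compound 4

A few compounds are considered here, and "the series" means these few. Any claim that something is new, unique, unknown or untested is made for them only; others in the source may bear on it.

Measured compounds:
compound 1 `Nc1ncc(C#Cc2c(F)cccc2F)c2ccccc12` 86.2%
compound 2 `Fc1cccc(F)c1C#Cc1cnc2ccccc2c1` 41.7%
compound 3 `Fc1cccc(F)c1C#Cc1cc2ccccc2nc1Cl` 28.4%

In a functional assay on LS174T cells (Homo sapiens) for inhibition, with a stated time of 4 days, tested at 1 uM (a higher number here means a stronger effect of the compound at the concentration tested, a lower number a weaker effect), compound 2 gives 41.7%, the second highest of the three numbers; compound 1 gives 86.2%, beyond the scatter above it, and compound 3 gives 28.4%, beyond the scatter below it. Compound 4 `Fc1cccc(F)c1C#Cc1cnc2ccccc2c1Cl` is not yet measured. It differs from compound 2 by chloro in place of hydrogen on an aromatic carbon. For the measured compounds named here, the one step that bears on this is a number 13.3 percentage points lower from compound 2 to compound 3 (beyond the scatter), the same change at another place on the shared core. The step to compound 4 is therefore expected to be modest and downward, or none beyond the scatter, a number 8.7 percentage points lower from compound 2 to compound 4 (within the scatter). Compound 4 is estimated at 33%, between 10% and 58%.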

Compound 4, a percentage reported as inhibition, at one concentration (the size of the read-out at that concentration, not a potency): 51.5%
Compound 4: middle estimate off by 18.5 percentage points, on the low side, and the stated range covers the measured number.
By their numbers in this assay, from the lowest: compound 3; then compounds 2 and 4 (each within the scatter of the next); then compound 1.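

In this assay chloro in place of hydrogen on this aromatic carbon, opposite the ring nitrogen, gives a number 9.8 percentage points higher from compound 2 to compound 4 (within the scatter) and so shows no loss here, whereas a number 13.3 percentage points lower from compound 2 to compound 3 (beyond the scatter) came from the same change at another place on the shared core. Among these compounds, then, the outcome of this change depends on where it is made. Nothing shown explains the difference between the two places.

On these data alone, whether a methyl or a methoxy group would read like chloro at this position remains open. So does whether chloro here would leave the number of compound 1 in place.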